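Swapping the aryl group on a benzylidene oxindole core

This account rests on a few compounds, and the source may have more. Where it says the series, first, only, none or still open, it means among the compounds named here.

Measured compounds:
- compound 1 `O=C1/C(=C\c2cccc(Br)c2)c2ccccc2N1c1c(Cl)cccc1Cl`: 7 ug/mL
- compound 2 `Cc1ccc2nc(Cl)c(/C=C3\C(=O)N(c4c(Cl)cccc4Cl)c4ccccc43)cc2c1`: "not determined" (no result reported)
- compound 3 `COc1ccc(/C=C2\C(=O)N(c3c(Cl)cccc3Cl)c3ccccc32)cc1OC`: "not determined" (no result reported)

Among the measured compounds shown here, compound 1 `O=C1/C(=C\c2cccc(Br)c2)c2ccccc2N1c1c(Cl)cccc1Cl` is the only member of this set with a numerical result. In a functional assay on MOLT-4 cells (Homo sapiens) for cytotoxicity, read by MTT assay, with a stated time of 72 h (a lower number here means that less compound is needed, a higher number that more compound is needed for the effect), compound 1 gives 7 ug/mL. Compound 2 `Cc1ccc2nc(Cl)c(/C=C3\C(=O)N(c4c(Cl)cccc4Cl)c4ccccc43)cc2c1` and compound 3 `COc1ccc(/C=C2\C(=O)N(c3c(Cl)cccc3Cl)c3ccccc32)cc1OC` share the same core but carry other aryl groups on the exocyclic double bond. In this assay compound 2 gives "not determined" (no result reported). In this assay compound 3 gives "not determined" (no result reported). Neither offers a comparison. Compound 1 therefore stands alone, with nothing above or below it to show how the aryl group steers the read-out.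

Compound 4 `O=C1/C(=C\c2ccccc2[N+](=O)[O-])c2ccccc2N1c1c(Cl)cccc1Cl` is the next compound to be examined. It differs from compound 1 in a single place: 2-nitrophenyl in place of 3-bromophenyl on a double-bonded chain carbon bound to a double-bonded ring carbon. For the measured compounds named here, the set holds no measured pair that differs in one place. Going by the values given here, no step is available to anchor a prediction. Among the compounds with values here, with only one number to lean on, the most defensible expectation is a change that stays within or just beyond the usual scatter, without a firm direction. For compound 4 the expected result in this assay is 8 ug/mL, with a plausible range from 3 ug/mL to 25 ug/mL. The implied change a 1.1-fold higher number from compound 1 to compound 4 (0.06 log units; within the scatter) is expected to be small.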

Compound 4, concentration for half-maximal effect: 6 ug/mL
For compound 4 the middle estimate is 1.3-fold (0.12 log units) above the measured one; the measured number falls inside the stated range.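

In this assay, among the compounds shown here, replacing 3-bromophenyl with 2-nitrophenyl on a double-bonded chain carbon bound to a double-bonded ring carbon gives a 1.2-fold lower number from compound 1 to compound 4 (0.07 log units; within the scatter), the first step that can be read at this position. The exchange is not a small one on paper: the bromine leaves, while a nitrogen and oxygen atoms enter, bringing hydrogen-bond acceptors where the leaving group has none, and yet the read-out of the shared core stays within the scatter for this one pair. No measurement at hand bears on why the two compounds read alike, and this single pair sets no rule for other aryl groups.

From the compounds shown here alone, compound 2 and compound 3 carry no result, so their aryl groups still add nothing to the comparison, and it remains open whether a larger step can be found at this position at all. Also open, going by these compounds, is how the read-out would respond to a phenyl group carrying an amine or a carboxylic acid, or to a longer chain in place of the aryl group on the same carbon.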